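Cyclopentyl to pyrrolidin-1-yl on the sulfonyl sulfur

The source may report more compounds than this note shows. Statements on the series, on what has been measured and on what is new or still open speak of the compounds shown alone.

In an ADME assay on microsomes from liver (Homo sapiens) for metabolic stability, read by LC-MS, with a stated time of 40 min, tested at 0.5 uM (on this read-out lower numbers stand for slow clearance and higher numbers for fast clearance), compound 1 `CC(C)(CO)S(=O)(=O)c1cccc(NC(=O)c2cccnc2N2CCC3(CC2)CC3)c1` gives 154 mL.min-1.g-1. Compound 2 `O=C(Nc1cccc(S(=O)(=O)NC2CC2)c1)c1cccnc1N1CCC2(CC1)CC2` reads > 399 mL.min-1.g-1, which is a limit and not a number. Compound 3 `O=C(Nc1cccc(S(=O)(=O)C2CCCC2)c1)c1cccnc1N1CCC2(CC1)CC2` reads > 399 mL.min-1.g-1, likewise a limit. Compound 3 thus stands at the limit of > 399 mL.min-1.g-1 in this assay, at which 2 of the 3 values shown sit.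

Compound 4 `O=C(Nc1cccc(S(=O)(=O)N2CCCC2)c1)c1cccnc1N1CCC2(CC1)CC2` carries pyrrolidin-1-yl in place of cyclopentyl on a sulfonyl sulfur.

Among the compounds with values here, the steps that bear on this change are an at least 2.5-fold higher number from compound 1 to compound 2 (0.41 log units; beyond the scatter) and an at least 2.5-fold higher number from compound 1 to compound 3 (0.41 log units; beyond the scatter), both beyond the scatter, while a step that the two limits leave unreadable from compound 2 to compound 3 gives no size. Both replacements of 1-(hydroxymethyl)-1-methylethyl ended at the limit, so no step beyond the scatter is expected here.

The expected step is a step that the limit leaves unreadable from compound 3 to compound 4.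

Compound 4 is estimated at 400 mL.min-1.g-1, within an expected range of 200 mL.min-1.g-1 to 800 mL.min-1.g-1, and may well return only a limit.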

Compound 4, intrinsic clearance in microsomes: > 399 mL.min-1.g-1
Compound 4 ended at the assay's limit (the forecaster's own chance of this, stated with the estimate: 70%); the middle value is on the limit's open side.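

In this assay the reading of compound 4 is a limit and not a number, so a sulfonamide nitrogen carrying the pyrrolidin-1-yl ring joins the groups at the limit on this sulfonyl sulfur: the limit of > 399 mL.min-1.g-1 in this assay, at which 3 of the 4 values shown sit.

Pyrrolidin-1-yl in place of 1-(hydroxymethyl)-1-methylethyl gives an at least 2.5-fold higher number from compound 1 to compound 4 (0.41 log units; beyond the scatter). The steps among compound 2, compound 3 and compound 4 cannot be read, so any difference between them stays hidden.

As far as these compounds go, whether morpholin-4-yl or a hydroxylated cyclopentyl on this sulfur would give a reading under the limit remains open. Also open, from the compounds shown here alone, is whether the hydroxyl of compound 1 or its branched carbon chain goes with its lower reading.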